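The compounds below may be only part of what the source reports. "The series", "measured", "known", "first", "only" and "open" are said of these compounds alone.

The measured compounds:

Compound 1 `CCC(CC)(CC(=O)Nc1cccc(OCc2ccc3c(F)cccc3n2)c1)C(=O)O`: in a functional assay on ileum (Cavia porcellus) for antagonist activity at cysteinyl leukotriene receptor (Homo sapiens) (on this read-out lower numbers stand for stronger inhibition and higher numbers for weaker inhibition), compound 1 gives 0.3 nM.
Compound 2 `CCC(CC)(CC(=O)Nc1cccc(OCc2ccc3cccc(F)c3n2)c1)C(=O)O`: in this assay compound 2 gives 6 nM.
Compound 3 `CCC(CC)(CC(=O)Nc1cccc(OCc2ccc3ccc(Br)cc3n2)c1)C(=O)O`: in this assay compound 3 gives 4 nM.

Among these three numbers compound 3 stands second highest. Its nearest neighbour is compound 2, whose number is only slightly higher, a gap that lies within the usual scatter, so the two cannot be told apart. The furthest is compound 1, whose far lower number lies well beyond the scatter.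

Compound 4 `CCC(CC)(CC(=O)Nc1cccc(OCc2ccc3ccccc3n2)c1)C(=O)O` has not yet been measured in this assay. It differs from compound 3 in one place: hydrogen in place of bromo on an aromatic carbon. For the measured compounds named here, no pair of measured compounds differs by such a change, so the three numbers give no direct guide to what the loss of a halogen from the fused ring does; compound 1 and compound 2 show only that two fluoro compounds can differ widely. In this assay the step from compound 3 to compound 4 is therefore expected to be small, within or close to the scatter, with no firm direction. Compound 4 is estimated at 5 nM, with a range from 1.5 nM to 20 nM. This estimate means an expected step of a 1.3-fold higher number from compound 3 to compound 4 (0.10 log units; within the scatter).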

Compound 4, half-maximal inhibitory concentration: 0.9 nM
For compound 4 the middle estimate is 5.6-fold (0.74 log units) above the measured one; measured number below the stated range.
By their numbers in this assay, from the lowest: compound 1; then compound 4; then compounds 3 and 2 (each within the scatter of the next).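

With compound 4 the shared core without any halogen on the fused system can finally be set against each halogen compound, and in this assay hydrogen in place of bromo gives a 4.4-fold lower number from compound 3 to compound 4 (0.65 log units; beyond the scatter), so bromo at this position goes with weaker inhibition than hydrogen. Hydrogen in place of fluoro gives a 6.7-fold lower number from compound 2 to compound 4 (0.82 log units; beyond the scatter) but also a 3.0-fold higher number from compound 1 to compound 4 (0.48 log units; beyond the scatter), so a halogen on this ring system has no single direction: compound 2 and compound 3 lie on the weaker side of compound 4, while compound 1 goes against that pattern and lies on the stronger side. No measurement is available that would explain why these steps differ in direction.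

The compounds shown leave open whether these steps follow the halogen itself or the carbon that carries it, as bromo and fluoro appear here on different carbons. From the compounds shown here alone, it also remains open where a chloro group or a methoxy group on these same carbons would fall relative to compound 4.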